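Swapping an amide substituent: lung exposure after oral dosing

The compounds below may be only part of what the source reports. "The series", "measured", "known", "first", "only" and "open" are said of these compounds alone.

Measured so far:
- compound 1 `NCc1cc(Oc2cccc(Oc3ccccc3)c2)nc(C(F)(F)F)c1`: "not determined" (no result reported)
- compound 2 `NCc1cc(Oc2cccc(C(=O)NCc3cc4ccccc4s3)c2)nc(C(F)(F)F)c1`: "not determined" (no result reported)
- compound 3 `NCc1cc(Oc2cccc(C(=O)N3CC[C@@H](N)C3)c2)nc(C(F)(F)F)c1`: 1230 nM

Three compounds share a core and differ only in the group hanging from one aromatic ring. In an ADME assay on the whole organism (lung, Mus musculus) for pharmacokinetics, read by LC-MS, at a dose of 30 mg/kg by the oral route (on this read-out lower numbers stand for lower exposure and higher numbers for higher exposure at the dose given), compound 1 is recorded as "not determined" (no result reported) and compound 2 as "not determined" (no result reported), so no number is available for either, and the only figure available is that of compound 3, which in this assay gives 1230 nM. Compound 3 therefore stands alone; nothing can be said about how it ranks against the others.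

Compound 4 `NCc1cc(Oc2cccc(C(=O)NC[C@@H](O)CO)c2)nc(C(F)(F)F)c1` is the next compound to be examined. The structural change from compound 3 to compound 4 is (2,3-dihydroxypropyl)amino in place of 3-aminopyrrolidin-1-yl on a carbonyl carbon. Nothing has been measured that shows what such a change does here. Without any comparable step to lean on, the expectation rests only on compound 3 and its value of 1230 nM, and the step from compound 3 to compound 4 is expected to be modest, at or near the edge of the usual scatter, with an estimated step of a 1.4-fold lower number from compound 3 to compound 4 (0.14 log units; within the scatter). Compound 4 is accordingly estimated at 900 nM, within a range of 300 nM to 2700 nM.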

Compound 4, maximal plasma concentration: 1920 nM
Beside the measured number, compound 4's estimate is 2.1-fold (0.33 log units) below it, and the stated range covers the measured number.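

In this assay, for the compounds shown here, putting (2,3-dihydroxypropyl)amino in place of 3-aminopyrrolidin-1-yl on the carbonyl carbon gives a 1.6-fold higher number from compound 3 to compound 4 (0.19 log units; within the scatter) and provides the first pair of numbers at this position. The result shows that this position can take an open chain with no ring in place of a five-membered non-aromatic ring, with two oxygens and one nitrogen in the entering group where the leaving group has two nitrogens, and the pair still cannot be told apart on this read-out. None of the information at hand bears on what lies behind this result.

Steps to compound 1 and compound 2 cannot be read, so this single pair is all there is to go on, and it cannot show whether the outcome holds for other groups on the carbonyl carbon. A carboxylic acid, a simple primary amine on a longer chain, or the mirror-image form of the (2,3-dihydroxypropyl)amino group could each stay within the usual scatter of compound 4 or move clearly away from it, and the compounds shown do not tell which.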